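Shortening the Side Chain: Butyl to Propyl

A few compounds are considered here, and "the series" means these few. Any claim that something is new, unique, unknown or untested is made for them only; others in the source may bear on it.

Measured compounds:
Compound 1 `CCCCc1csc(CN[C@@H]2C[C@H]3C[C@@H]([C@H]2C)C3(C)C)c1` gives 12500 nM in an ADME assay on MDCK cells (Canis lupus familiaris) for cytotoxicity, read by microscopy, with a stated time of 48 h; a lower number here means that less compound is tolerated, a higher number that more compound is tolerated.
Compound 2 `C[C@H]1[C@H](NCc2ccc(C(C)(C)C)s2)C[C@H]2C[C@@H]1C2(C)C` gives 780 nM in this assay.
Compound 3 `C[C@H]1[C@H](NCc2ccc(Br)s2)C[C@H]2C[C@@H]1C2(C)C` gives 43000 nM in this assay.

Among these three numbers compound 1 stands second highest, closer to compound 3 than to compound 2. For the measured compounds named here, the one measured step with a single change, a 55-fold higher number from compound 2 to compound 3 (1.74 log units; beyond the scatter), is large, but it concerns bromo replacing tert-butyl on the ring, not a chain. Compound 4 `CCCc1csc(CN[C@@H]2C[C@H]3C[C@@H]([C@H]2C)C3(C)C)c1` differs from compound 1 by hydrogen in place of methyl on a saturated chain carbon, three bonds along the chain from an aromatic carbon. Going by the values given here, no measured step involves a chain shortened from butyl to propyl, so nothing here bears directly on it, and such a change is expected to be modest. Compound 4 is therefore expected to sit near compound 1, the expected step being a 1.2-fold higher number from compound 1 to compound 4 (0.08 log units; within the scatter), within the scatter. The estimate for compound 4 is 15000 nM, expected between 6000 nM and 40000 nM.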

Compound 4, minimum cytotoxic concentration: 12500 nM
For compound 4 the middle estimate is 1.2-fold (0.08 log units) above the measured one; the measured number falls inside the stated range.
By their numbers in this assay, from the lowest: compound 2; then compounds 1 and 4 (each within the scatter of the next); then compound 3.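

In this assay, going from butyl to propyl gives no change at the digits printed from compound 1 to compound 4 (within the scatter), so at this position on the chain, hydrogen in place of methyl leaves the read-out where it was. The earlier step, a 55-fold higher number from compound 2 to compound 3 (1.74 log units; beyond the scatter), concerned a group on the ring, so this is the only view of the chain itself. Nothing measured here offers an explanation for this result.

Going by these compounds, whether a still shorter chain such as ethyl would behave the same remains open. So does the outcome for a longer chain, or for a chain ending in an amine or a carboxylic acid.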